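Replacing 4-(dimethylamino)phenyl in a series held at the limit

A few compounds are considered here, and "the series" means these few. Any claim that something is new, unique, unknown or untested is made for them only; others in the source may bear on it.

Values from a functional assay on DU-145 cells (Homo sapiens) for inhibition, read by trypan blue exclusion, with a stated time of 96 h (on this read-out higher numbers stand for weaker inhibition of growth and lower numbers for stronger inhibition of growth), are all limits here:
- compound 1 (`Cc1ccc(S/C(=C/c2ccc(N(C)C)cc2)C(=O)c2ccc(Cl)cc2)cc1`) gives > 100000 nM as a limit
- compound 2 (`CN(C)c1ccc(/C=C(\C(=O)c2ccc(Cl)cc2)S(=O)(=O)c2ccc(Br)cc2)cc1`) gives > 100000 nM as a limit
- compound 3 (`Cc1ccc(S(=O)(=O)/C(=C/c2ccc(N(C)C)cc2)C(=O)c2ccc(Cl)cc2)cc1`) gives > 100000 nM as a limit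

Compound 1 has only a limit and no readable number, and the other two measured compounds share that position (the limit of > 100000 nM in this assay, at which 3 of the 3 values shown sit). Compound 4 (`Cc1ccc(S/C(=C/c2ccc(Cl)cc2Cl)C(=O)c2ccc(Cl)cc2)cc1`) differs from compound 1 in one place (2,4-dichlorophenyl in place of 4-(dimethylamino)phenyl on a double-bonded chain carbon bound to a double-bonded chain carbon), on a double-bonded chain carbon bound to a double-bonded chain carbon. The measured steps (a step that the two limits leave unreadable from compound 1 to compound 2; a step that the two limits leave unreadable from compound 1 to compound 3; a step that the two limits leave unreadable from compound 2 to compound 3) have no readable size and leave the 4-(dimethylamino)phenyl untouched, so they offer no size to carry over. All three measured compounds carry that group, and compound 4 alone carries 2,4-dichlorophenyl instead. Compound 1 gives > 100000 nM as a limit, so a readable number for compound 4 could only mean stronger inhibition of growth in this assay and this is the expected direction. The estimated step (an at least 3.3-fold lower number from compound 1 to compound 4 (0.52 log units; beyond the scatter)) is therefore tentative. Compound 4 is expected at 30000 nM with an estimated range from 4000 nM to 100000 nM and a further limit remains possible.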

Compound 4, concentration for 50% growth inhibition: 10000 nM
For compound 4 the middle estimate is 3.0-fold (0.48 log units) above the measured one; the measured number falls inside the stated range.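

In this assay, for the compounds shown here, the change at this position gives the first readable number, with an at least 10-fold lower number from compound 1 to compound 4 (1.00 log units; beyond the scatter). The steps among compound 1, compound 2 and compound 3 cannot be read, and all three keep 4-(dimethylamino)phenyl; among the compounds shown, only the place on a double-bonded chain carbon bound to a double-bonded chain carbon has moved the read-out off the limit. The size of the step remains a minimum, and most of the set stays at that ceiling: the limit of > 100000 nM in this assay, at which 3 of the 4 values shown sit.

Still open, going by these compounds, is whether the result follows from the two chlorines or from the loss of 4-(dimethylamino)phenyl; a plain phenyl or a 4-methoxyphenyl at this place would help separate the two. On these data alone, it is also open whether the sulfonyl and sulfanyl links behave alike once 2,4-dichlorophenyl is present.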